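Swapping a thiazole for a pyridine on the sulfonamide

The compounds below may be only part of what the source reports. "The series", "measured", "known", "first", "only" and "open" are said of these compounds alone.

Measured compounds:
Compound 1 `N#Cc1c(-c2ccccc2)cn(-c2ccc(S(=O)(=O)Nc3nccs3)cc2)c1N`: 3490 nM in a functional assay on MCF7 cells (Homo sapiens) for inhibition, read by sulforhodamine B assay, with a stated time of 24 h; on this read-out higher numbers stand for weaker inhibition and lower numbers for stronger inhibition
Compound 2 `O=c1[nH]cnc2c1c(-c1ccccc1)cn2-c1ccc(S(=O)(=O)Nc2nccs2)cc1`: 6210 nM in this assay

Both compounds share a core with a phenyl group and a sulfonamide-bearing aryl ring; they differ in the bicyclic part. Compound 2 gives the larger of the two numbers, but the gap to compound 1 lies within the usual scatter of this assay, so the two cannot be told apart on these data.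

Compound 3 `O=c1[nH]cnc2c1c(-c1ccccc1)cn2-c1ccc(S(=O)(=O)Nc2ccccn2)cc1` keeps the core of compound 2 and changes only the group on the sulfonamide nitrogen: pyridin-2-yl in place of 1,3-thiazol-2-yl on a sulfonamide nitrogen. Within the data shown here, no measured pair shows what this particular exchange does in this assay, so there is no step to lean on. The change is small and conservative, and with no other guide, no step beyond the scatter is expected. The step from compound 2 to compound 3 is estimated as a 1.1-fold higher number from compound 2 to compound 3 (0.05 log units; within the scatter). Compound 3 is therefore expected to give about 7000 nM, with a range from 2500 nM to 20000 nM.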

Compound 3, half-maximal inhibitory concentration: 5320 nM
Compound 3: the middle estimate sits 1.3-fold (0.12 log units) above what was measured, and the stated range covers the measured number.
By their numbers in this assay, from the lowest: compounds 1, 3 and 2 (each within the scatter of the next).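

In this assay, the group on the sulfonamide nitrogen can change from 1,3-thiazol-2-yl to pyridin-2-yl without a readable shift (a 1.2-fold lower number from compound 2 to compound 3 (0.07 log units; within the scatter)). Compound 1 and compound 2 carry the same group at this place, so this pair alone gives a view of it, and here a six-membered aromatic ring with one hetero atom cannot be told apart from a five-membered one with two. Nothing measured here explains why the two groups give such similar numbers.

Going by these compounds, both groups are aromatic rings, so it remains open whether a methyl group or a chain ending in a carboxylic acid on the same nitrogen would leave the number unchanged. On these data alone, it is also open whether the same exchange would give a similar result on the core of compound 1.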